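This account rests on a few compounds, and the source may have more. Where it says the series, first, only, none or still open, it means among the compounds named here.

The three measured compounds share one core and differ only in the aryl group on the carbon that bears the double bond to nitrogen. Within the data shown here, compound 1, `Cc1ccc(/C=N/N=C(\N)CC(O)c2cccc3ccccc23)cc1`, is the one with the lowest number in an ADME assay on L6 cells (Rattus norvegicus) for cytotoxicity, read by resazurin assay, with a stated time of 72 h; a higher number here means a weaker inhibitor, a lower number a stronger inhibitor: there compound 1 gives 6800 nM. Compound 3, `COc1ccc(/C=N/N=C(\N)CC(O)c2ccc3ccccc3c2)cc1`, gives in this assay a value of 69000 nM, and compound 2, `CCOc1cc(/C=N/N=C(\N)CC(O)c2ccc3ccccc3c2)ccc1O`, gives 78000 nM. Both of those numbers lie beyond the scatter above the number for compound 1, so compound 1 stands apart as the strongest inhibitor of the three in this assay.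

Compound 4, `N/C(CC(O)c1cccc2ccccc12)=N\N=C\c1cccc(Br)c1`, has not yet been measured. It differs from compound 1 in one place: 3-bromophenyl in place of 4-methylphenyl on a carbon with a double bond to nitrogen. Among the measured compounds shown here, no pair among the measured compounds isolates that kind of change, so there is no measured step to lean on. The expectation is therefore that the step from compound 1 to compound 4 in this assay stays within the usual scatter, a 1.2-fold lower number from compound 1 to compound 4 (0.09 log units; within the scatter), with a slight lean toward a lower number. For compound 4 the estimate in this assay is 5500 nM, within a range from 1800 nM to 17000 nM.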

Compound 4, half-maximal inhibitory concentration: 3900 nM
The estimate for compound 4 lay 1.4-fold (0.15 log units) above the measured number; the range from low to high includes it.
By their numbers in this assay, from the lowest: compounds 4 and 1 (each within the scatter of the next); then compounds 3 and 2 (each within the scatter of the next).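

The exchange of 4-methylphenyl for 3-bromophenyl on a carbon with a double bond to nitrogen gives the first one-place step available in this assay, and it reads a 1.7-fold lower number from compound 1 to compound 4 (0.24 log units; within the scatter). This shows that, on the core of compound 1, one aryl group can replace the other at this position with no change beyond the scatter, so the two compounds cannot be ranked against each other. No measurement is at hand that bears on the reason for this result.

On these data alone, whether the position responds differently to a group of another kind, such as an amine, a carboxylic acid or a longer chain, remains open. Also open, as far as these compounds go, is whether the same exchange would give a similar step on the core of compound 3, which differs from compound 1 in more than one place.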